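Phenethyl to dimethylamino in an amide and an amine analogue

This account rests on a few compounds, and the source may have more. Where it says the series, first, only, none or still open, it means among the compounds named here.

Values in a functional assay (brain) for inhibition, with Rattus norvegicus as the target (a higher number here means a weaker inhibitor, a lower number a stronger inhibitor), so far:
compound 1 `Cc1c(C)c2c(c(C)c1O)CCC(C)(C(=O)NCCCCc1ccccc1)O2` gives 700 nM
compound 2 `Cc1c(C)c2c(c(C)c1O)CCC(C)(C(=O)NCCN(C)C)O2` gives 8700 nM
compound 3 `Cc1c(C)c2c(c(C)c1O)CCC(C)(CNCCCCc1ccccc1)O2` gives 800 nM

Compound 1 and compound 2 differ in a single place: dimethylamino in place of phenethyl on a saturated chain carbon, two bonds along the chain from an amide-type nitrogen. This change produced a 12-fold higher number from compound 1 to compound 2 (1.09 log units; beyond the scatter), a clear loss of inhibition.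

Compound 3 carries a different core from compound 1; that difference is not broken down here. The values of compound 3 and compound 1 in this assay lie within the scatter of each other, so the two are not distinguished.

Compound 4 `Cc1c(C)c2c(c(C)c1O)CCC(C)(CNCCN(C)C)O2` is not yet measured. It differs from compound 3 by dimethylamino in place of phenethyl on a saturated chain carbon, two bonds along the chain from an amine nitrogen. Within the data shown here, the change is of the same kind as the one from compound 1 to compound 2, but the surroundings differ: there the position was two bonds along the chain from an amide-type nitrogen, here it is two bonds along the chain from an amine nitrogen.

Among the measured compounds shown here, with only one precedent, the expectation rests on the single step seen from compound 1 to compound 2, a 12-fold higher number from compound 1 to compound 2 (1.09 log units; beyond the scatter). For compound 4 a step of about a 10-fold higher number from compound 3 to compound 4 (1.00 log units; beyond the scatter) is expected, landing at an estimated 8000 nM in this assay, with a range from 2500 nM to 25000 nM.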

Compound 4, half-maximal inhibitory concentration: 1700 nM
The estimate for compound 4 lay 4.7-fold (0.67 log units) above the measured number; measured number below the stated range.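

Dimethylamino in place of phenethyl gives a 2.1-fold higher number from compound 3 to compound 4 (0.33 log units; beyond the scatter) in this assay, so the change again gives a higher number on the core of compound 3, but by less. The direction carries over between the two cores, while the size does not: the same change on two cores in this assay, a 12-fold higher number (1.09 log units; beyond the scatter) from compound 1 to compound 2 and a 2.1-fold higher number (0.33 log units; beyond the scatter) from compound 3 to compound 4, 5.8-fold (0.77 log units) apart, beyond the scatter of two such steps

Among these compounds, with only two pairs, this shows that the step measured on one core is a poor guide to its size on the other, but it gives no rule for any further core and does not identify which part of the core accounts for the gap.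

The compounds shown leave open whether the two cores also diverge with other chain ends, such as a piperidine, a carboxylic acid or a longer chain ending in dimethylamino. They also do not separate the loss of the phenyl ring from the gain of the amine nitrogen, a question that a plain alkyl chain end could address.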